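A few compounds are considered here, and "the series" means these few. Any claim that something is new, unique, unknown or untested is made for them only; others in the source may bear on it.

Measured compounds:

- compound 1, `CCc1ccc(-n2nc(-c3ccc(C(F)(F)F)cc3O)nc2-c2ccccc2O)cc1`: in a functional assay on PC-12 cells (Rattus norvegicus) for cytotoxicity, read by MTT assay, with stated times of 2 h and 24 h, tested at 1 uM (a higher number here means a stronger effect of the compound at the concentration tested, a lower number a weaker effect), compound 1 gives 64.4%
- compound 2, `Oc1cc(C(F)(F)F)ccc1-c1nc(-c2ccccc2O)n(-c2ccc(Br)cc2)n1`: in this assay compound 2 gives 69.4%
- compound 3, `Oc1cc(C(F)(F)F)ccc1-c1nc(-c2ccccc2O)n(-c2ccc(I)cc2)n1`: in this assay compound 3 gives 70.1%

Compound 3 holds the highest of the three numbers, but the nearest, compound 2, sits a number 0.7 percentage points higher from compound 2 to compound 3 (within the scatter) and the furthest, compound 1, sits a number 5.7 percentage points higher from compound 1 to compound 3 (within the scatter); with every gap within the scatter, no ordering among the three can be read from these numbers.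

The step to compound 4, `Oc1cc(C(F)(F)F)ccc1-c1nc(-c2ccccc2O)n(-c2ccc(OC(F)(F)F)cc2)n1`, is trifluoromethoxy in place of iodo on an aromatic carbon. The change sits on an aromatic carbon of a six-membered aromatic ring of carbon only, para to a large group, the same place varied in all three measured steps. Those steps are a number 5 percentage points higher from compound 1 to compound 2 (within the scatter), a number 5.7 percentage points higher from compound 1 to compound 3 (within the scatter) and a number 0.7 percentage points higher from compound 2 to compound 3 (within the scatter); each lies within the scatter. Exchange of ethyl, bromo and iodo at this place therefore moved nothing that can be told from noise. Trifluoromethoxy is untested here, and the three measured groups give no direction to lean on.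

The expectation for compound 4 is accordingly a step of a number 3.1 percentage points lower from compound 3 to compound 4 (within the scatter), no larger than the scatter. Compound 4 is estimated at 67%, with a range from 55% to 78%.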

Compound 4, a percentage reported as activity, at one concentration (the size of the read-out at that concentration, not a potency): 65.5%
The estimate for compound 4 lay 1.5 percentage points above the measured number; measured number inside the range.
By their numbers in this assay, from the lowest: compounds 1, 4, 2 and 3 (each within the scatter of the next).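

Trifluoromethoxy differs from iodo in more than size at this place on the aromatic carbon, para to a large group: it enters with more heavy atoms and a hydrogen-bond acceptor, where iodo has none. Even so, this assay does not separate it from any of the three earlier groups, with a number 4.6 percentage points lower from compound 3 to compound 4 (within the scatter) and a number 3.9 percentage points lower from compound 2 to compound 4 (within the scatter) and a number 1.1 percentage points higher from compound 1 to compound 4 (within the scatter) as its steps, so the flat picture from ethyl, bromo and iodo now also covers a group joined through oxygen. No measurement on hand bears on why these four groups cannot be told apart at this place.

On these data alone, whether a primary amine, a carboxylic acid or a longer alkyl chain at this place would move the read-out beyond the scatter stays open, as does the effect of any change to the shared core, which is the same in all four compounds. All four numbers also come from a single concentration, so they give the size of the read-out there and leave any difference in potency among the compounds unresolved.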